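A few compounds are considered here, and "the series" means these few. Any claim that something is new, unique, unknown or untested is made for them only; others in the source may bear on it.

Measured so far in a functional assay on OVCAR-5 cells (Homo sapiens) for cytotoxicity, read by sulforhodamine B assay, with a stated time of 48 h; on this read-out higher numbers stand for lower toxicity in this test and lower numbers for higher toxicity in this test:
compound 1, `ClCc1ccc(Cn2cnc3c(Cl)ncnc32)cc1`, gives 34700 nM
compound 2, `ClCc1ccccc1Cn1cnc2c(Cl)nc(Cl)nc21`, gives 5620 nM

Compound 2 holds the lowest of the two numbers in this assay; the other, compound 1, lies clearly higher, beyond the usual scatter. Compound 3, `ClCc1ccccc1Cn1cnc2c(Cl)ncnc21`, has not been measured. It differs from compound 2 by hydrogen in place of chloro on an aromatic carbon, between two ring nitrogen atoms, meta to a chloro group, meta to a fused ring and para to a fused ring. Going by the values given here, no measured pair isolates this single change: compound 1 and compound 2 differ both in this chloro and in the position of the chloromethyl on the benzyl ring, so their two values give only a hint of direction. A moderate step upward in this assay, toward lower toxicity and possibly beyond the scatter, is expected for compound 3, estimated as a 2.7-fold higher number from compound 2 to compound 3 (0.43 log units; beyond the scatter). The expected value for compound 3 is 15000 nM, within 5000 nM to 45000 nM.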

Compound 3, concentration lethal to 50% of the cells: 25700 nM
Estimate against measurement, compound 3: 1.7-fold (0.23 log units) below, and the stated range covers the measured number.
By their numbers in this assay, from the lowest: compound 2; then compounds 3 and 1 (each within the scatter of the next).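

In this assay, going by these compounds alone, replacing the chloro on the aromatic carbon between two ring nitrogen atoms with hydrogen gives a 4.6-fold higher number from compound 2 to compound 3 (0.66 log units; beyond the scatter); this is the first reading of this change alone, and at this position hydrogen goes with lower toxicity in this test than chloro. Compound 3 at 25700 nM and compound 1 at 34700 nM lie within the scatter of each other, so without this chloro the two placements of the chloromethyl group are not told apart in this test. No measurement available here explains the step.

As far as these compounds go, only chloro and hydrogen appear on this carbon, so how an amine or a methoxy group there would read remains open. From the compounds shown here alone, whether the chloro step carries over to the chloromethyl placement of compound 1 also remains open.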